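The compounds below may be only part of what the source reports. "The series", "measured", "known", "first", "only" and "open" are said of these compounds alone.

Three compounds of a shared core were measured in a functional assay on K562 cells (Homo sapiens) for antiproliferative activity, read by CCK-8 assay, with a stated time of 72 h; on this read-out lower numbers stand for stronger inhibition of growth and higher numbers for weaker inhibition of growth. Compound 1 `CCCCNS(=O)(=O)c1ccc(Nc2ncc3c(n2)N(c2ccn(C)n2)C(CC)C(=O)N3C)cc1` gives 4240 nM, compound 3 `CCCCNC(=O)c1ccc2c(ccn2-c2ncc3c(n2)N(c2ccn(C)n2)C(CC)C(=O)N3C)c1` gives 14100 nM, and compound 2 `CC[C@@H]1C(=O)N(C)c2cnc(-n3ccc4cc(C(=O)NC(C)C)ccc43)nc2N1C1CCCC1` gives 786 nM, the lowest of the three numbers, with both neighbours lying beyond the scatter. Compound 4 `CC[C@@H]1C(=O)N(C)c2cnc(-n3ccc4cc(C(N)=O)ccc43)nc2N1C1CCCC1` has not yet been measured. It differs from compound 2 in one place: hydrogen in place of isopropyl on an amide-type nitrogen. Among the compounds with values here, with no measured step of this kind available, the expected step of a 1.9-fold higher number from compound 2 to compound 4 (0.28 log units; within the scatter) is a small rise, close to the edge of the scatter. On that basis compound 4 is estimated at 1500 nM in this assay, with a range from 500 nM to 5000 nM.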

Compound 4, concentration for 50% growth inhibition: 1850 nM
The estimate for compound 4 lay 1.2-fold (0.09 log units) below the measured number, and the stated range covers the measured number.
By their numbers in this assay, from the lowest: compound 2; then compound 4; then compound 1; then compound 3.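

Going from isopropylcarbamoyl to carbamoyl in this assay gives a 2.4-fold higher number from compound 2 to compound 4 (0.37 log units; beyond the scatter), the first single-place comparison in this set. It shows that the number responds to the group on this amide-type nitrogen, yet the modest size of the step means that growth inhibition does not depend entirely on the isopropyl. Nothing available gives a reason for this step.

The compounds shown leave open how a longer chain, a cyclopropyl ring or a chain bearing an amine would read on this nitrogen. They also leave open whether a carboxylic acid could replace the amide.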